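This account rests on a few compounds, and the source may have more. Where it says the series, first, only, none or still open, it means among the compounds named here.

Among the compounds with values here, of the two compounds measured so far, compound 2 `Cc1c(C)c2c(c(C)c1OC(=O)CCC(=O)O)CCC(C)(COc1ccc(/C=C3\SC(=O)NC3=O)cc1)O2` stands highest in a functional assay on MCF7 cells (Homo sapiens), tested at 5 uM (a higher number here means a weaker effect of the compound at the concentration tested, a lower number a stronger effect), where compound 2 gives 98%. Within the data shown here, its nearest neighbour is compound 1 `CC(C)=CCOc1c(C)c(C)c2c(c1C)CCC(C)(COc1ccc(/C=C3\SC(=O)NC3=O)cc1F)O2`, which in this assay gives 87%, a number lower by a margin beyond the usual scatter; the two structures differ in more than one place, so no single step links them. Compound 3 `Cc1c(C)c2c(c(C)c1OCc1ccccc1)CCC(C)(COc1ccc(/C=C3\SC(=O)NC3=O)cc1)O2` has not yet been measured. It differs from compound 2 at one place: benzyl in place of (2-carboxyethyl)carbonyl on an oxygen on an aromatic ring. Among the measured compounds shown here, no measured pair shows the outcome of such an exchange, so any expectation can rest only on the two numbers at hand. Compound 3 is expected to give a somewhat lower reading, a step of a number 10 percentage points lower from compound 2 to compound 3 (within the scatter), because compound 1, which also carries no carboxylic acid, already gives 87%. The estimate for compound 3 is therefore 88%, within a range from 72% to 100%.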

Compound 3, a percentage reported as activity, at one concentration (the size of the read-out at that concentration, not a potency): 42%
The estimate for compound 3 lay 46 percentage points above the measured number; measured number below the stated range.
By their numbers in this assay, from the lowest: compound 3; then compound 1; then compound 2.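

At the oxygen on an aromatic ring, benzyl in place of (2-carboxyethyl)carbonyl gives in this assay a number 56 percentage points lower from compound 2 to compound 3 (beyond the scatter), the first single-place change available in this set. It shows that this position strongly affects the read-out, even though the two groups have the same heavy-atom count and differ in their atoms, their hydrogen-bond donor and acceptors, and the aromatic ring. Nothing shown gives a cause for this step.

As far as these compounds go, this one exchange removes the carboxylic acid and adds the aromatic ring together, so their separate contributions remain open. A simple ester lacking the carboxylic acid, a methyl ether, a longer alkyl chain or a phenethyl group on the same oxygen would each bear on that question.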